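The source may hold more compounds than are shown below. What is called first, only, known or untested is meant among the compounds shown, and "the series" means these compounds.

Of the compounds shown here, three built on one shared core have been tested in a functional assay on PC-12 cells (Rattus norvegicus) for cytotoxicity, read by MTT assay, with stated times of 2 h and 24 h, tested at 5 uM; on this read-out lower numbers stand for a weaker effect and higher numbers for a stronger effect at the one concentration tested. Compound 1 `CCc1ccc(-n2nc(-c3ccc(C(F)(F)F)cc3O)nc2-c2ccccc2O)cc1` gives 95.4% in this assay, compound 2 `CC(C)(C)c1ccc(-n2nc(-c3ccc(C(F)(F)F)cc3O)nc2-c2ccccc2O)cc1` gives 77.8%, and compound 3 `Oc1cc(C(F)(F)F)ccc1-c1nc(-c2ccccc2O)n(-c2ccc(F)cc2)n1` gives 86.7%. On these numbers compound 3 stands second highest of the three, but within the scatter of both others. Compound 4 `Oc1cc(C(F)(F)F)ccc1-c1nc(-c2ccccc2O)n(-c2ccc(OC(F)(F)F)cc2)n1` differs from compound 3 in one place: trifluoromethoxy in place of fluoro on an aromatic carbon. All three measured steps exchange the group on this same aromatic carbon, so each bears on the change. Exchanging ethyl for tert-butyl gave a number 17.6 percentage points lower from compound 1 to compound 2 (beyond the scatter); exchanging ethyl for fluoro gave a number 8.7 percentage points lower from compound 1 to compound 3 (within the scatter); exchanging tert-butyl for fluoro gave a number 8.9 percentage points higher from compound 2 to compound 3 (within the scatter). One exchange at this carbon lowered the number beyond the scatter and two left it within the scatter, so a small drop or no change beyond the scatter is expected here, the expected step being a number 4.7 percentage points lower from compound 3 to compound 4 (within the scatter). Compound 4 is therefore estimated at 82%, with a range from 68% to 95%.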

Compound 4, a percentage reported as activity, at one concentration (the size of the read-out at that concentration, not a potency): 84.9%
Compound 4: the middle estimate sits 2.9 percentage points below what was measured; measured number inside the range.
By their numbers in this assay, from the lowest: compounds 2, 4, 3 and 1 (each within the scatter of the next, the first and the last beyond it).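

In this assay, trifluoromethoxy, with five heavy atoms and a hydrogen-bond acceptor, replaces the single fluorine on this aromatic carbon para to a large group, and the result is a number 1.8 percentage points lower from compound 3 to compound 4 (within the scatter); this much larger group therefore leaves the read-out within the scatter of fluoro. Compared with tert-butyl, the exchange gives a number 7.1 percentage points higher from compound 2 to compound 4 (within the scatter), whereas compared with ethyl it gives a number 10.5 percentage points lower from compound 1 to compound 4 (beyond the scatter), so compounds 2 and 4 both lie beyond the scatter of compound 1, while compound 3 does not. No available evidence explains why these groups give these numbers.

An amine, a carboxylic acid or a longer alkyl chain on this carbon remains an open case. On these data alone, whether trifluoromethoxy would behave the same way at another place on the shared core also remains unknown.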